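The compounds below may be only part of what the source reports. "The series", "measured", "known", "first", "only" and "open" are said of these compounds alone.

Compound 1 `CC(C)C(NC(=O)NO)C(=O)NC1CCCCC1`: > 100000 nM
Compound 2 `CCC(C)C(NC(=O)NO)C(=O)NC1CCCCC1`: > 100000 nM
Compound 3 `CCC(C)C1NC(=O)N(C2CCCC2)C1=O`: > 100000 nM

Of the compounds shown here, three have been measured in a functional assay on MIA PaCa-2 cells (Homo sapiens) for inhibition; on this read-out higher numbers stand for weaker inhibition and lower numbers for stronger inhibition. Compound 1 gives > 100000 nM, which is a limit of the assay and not a number. Compound 2 gives > 100000 nM, likewise only a limit. Compound 3 gives > 100000 nM, again a limit. The change from compound 2 to compound 1 is hydrogen in place of methyl on a saturated chain carbon, three bonds along the chain from an amide-type nitrogen and a carbonyl carbon; its step that the two limits leave unreadable from compound 2 to compound 1 cannot be read, because the limit of > 100000 nM in this assay, at which 3 of the 3 values shown sit, leaves no number on either side. How the core of compound 3 differs from that of compound 2 is not broken down here.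

Compound 4 `CC(C)C1NC(=O)N(C2CCCC2)C1=O` is not yet measured. It differs from compound 3 by hydrogen in place of methyl on a saturated chain carbon, two bonds along the chain from a saturated ring carbon. This is the same kind of change as that from compound 2 to compound 1, but not the same: there the carbon sits three bonds along the chain from an amide-type nitrogen and a carbonyl carbon, here two bonds along the chain from a saturated ring carbon. With the earlier step unreadable, the expectation for compound 4 rests on (the limit of > 100000 nM in this assay, at which 3 of the 3 values shown sit). The step from compound 3 to compound 4 is expected to be a step that the limit leaves unreadable from compound 3 to compound 4 in this assay. Compound 4 is therefore expected to give about 150000 nM, between 50000 nM and 500000 nM, most likely as a limit again.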

Compound 4, half-maximal inhibitory concentration: > 100000 nM
Compound 4 ended at the assay's limit; the forecaster's own chance of this, stated with the estimate: 90%; the middle value is on the limit's open side.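

In this assay compound 4 gives > 100000 nM, which is a limit of the assay and not a number. No step can be read from compound 3 to compound 4: the limit of > 100000 nM in this assay, at which 4 of the 4 values shown sit.

The compounds shown leave open how far any of them lies beyond that limit, and whether any structural change would yield a measurable value in this assay.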